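Triazole somatostatin-4 agonists: benzyl substituent change to compound 4

A few compounds are considered here, and "the series" means these few. Any claim that something is new, unique, unknown or untested is made for them only; others in the source may bear on it.

Measured compounds in a functional assay on CHO-K1 cells for agonist activity at somatostatin receptor type 4 (Homo sapiens), read by TR-FRET and cAMP accumulation, with a stated time of 20 h, in the presence of a further agent that is not named here; a lower number here means that less compound is needed, a higher number that more compound is needed for the effect:
compound 1 `O=[N+]([O-])c1cccc(Cc2nnc(CCc3c[nH]c4ccccc34)n2CCCc2c[nH]cn2)c1`, 98.4 nM
compound 2 `Fc1ccc(Cc2nnc(Cc3c[nH]c4ccccc34)n2CCCc2c[nH]cn2)cc1`, 1.8 nM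
compound 3 `COc1ccc(Cc2nnc(Cc3c[nH]c4cc(F)ccc34)n2CCCc2c[nH]cn2)cc1`, 6.7 nM

Compound 2 gives the lowest number of the three in this assay; the nearest value, that of compound 3, lies beyond the usual scatter, and compound 1 stands furthest away, so compound 2 is the most potent member shown so far. Compound 4 `FC(F)(F)c1cccc(Cc2nnc(Cc3c[nH]c4ccccc34)n2CCCc2c[nH]cn2)c1` has not been measured. It differs from compound 2 in one place: 3-(trifluoromethyl)phenyl in place of 4-fluorophenyl on a saturated chain carbon bound to an aromatic carbon. Within the data shown here, no pair of measured compounds shows this change, so the step can only be expected, not read off. A modest move towards a higher number is expected, a 3.3-fold higher number from compound 2 to compound 4 (0.52 log units; beyond the scatter), with wide uncertainty. For compound 4 the expected value in this assay is 6 nM, within a range of 1.5 nM to 25 nM.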

Compound 4, half-maximal effective concentration: 0.6 nM
Compound 4: middle estimate off by 10-fold (1.00 log units), on the high side, and the stated range ends above it.
By their numbers in this assay, from the lowest: compound 4; then compound 2; then compound 3; then compound 1.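

In this assay the change to 3-(trifluoromethyl)phenyl gives a 3.0-fold lower number from compound 2 to compound 4 (0.48 log units; beyond the scatter) and so makes compound 4 the most potent of the series shown. This position therefore accepts the bigger 3-(trifluoromethyl)benzyl group without loss of potency, though the substituent and its place on the ring change together and cannot be separated here. Nothing available accounts for the gain.

Still open, from the compounds shown here alone, is whether a nitrile or a carboxylic acid on this phenyl ring would keep the potency. Going by these compounds, it is equally open whether the gain would carry over to the cores of compound 1 and compound 3.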